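Carboxy in place of hydroxymethyl on a shared core

A few compounds are considered here, and "the series" means these few. Any claim that something is new, unique, unknown or untested is made for them only; others in the source may bear on it.

Three analogues share one core and have been measured in a functional assay on JeKo-1 cells (Homo sapiens) for inhibition, read by luminescence and CellTiter-Glo, with a stated time of 72 h; on this read-out lower numbers stand for stronger inhibition and higher numbers for weaker inhibition. Compound 1 `C=CC(=O)Nc1ccc(Cn2nc(-c3ccc(Oc4ccccc4)cc3)cc2C(=O)O)cc1` reaches only a limit there: in this assay compound 1 gives > 60000 nM. Compound 2 `C/C=C/C(=O)Nc1cccc(Cn2nc(-c3ccc(Oc4ccccc4)cc3)cc2C(=O)O)c1` likewise reaches only a limit, giving > 60000 nM in this assay. Going by the values given here, compound 3 `C=CC(=O)Nc1cccc(Cn2nc(-c3ccc(Oc4ccccc4)cc3)cc2CO)c1` is the one analogue with a number, giving 5200 nM in this assay; two of the three values sit at the limit of > 60000 nM in this assay, at which 2 of the 3 values shown sit. Compound 4 `C=CC(=O)Nc1cccc(Cn2nc(-c3ccc(Oc4ccccc4)cc3)cc2C(=O)O)c1` differs from compound 3 by carboxy in place of hydroxymethyl on an aromatic carbon. Among the compounds with values here, no measured pair isolates this change, yet compound 1 and compound 2 both carry carboxy and both sit at the limit, so a loss in this assay is expected, with the step of a 12-fold higher number from compound 3 to compound 4 (1.06 log units; beyond the scatter). Compound 4 is thus expected near 60000 nM, within 15000 nM to 200000 nM.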

Compound 4, half-maximal inhibitory concentration: > 60000 nM
Compound 4: only a limit was reported (the forecaster's own chance of this, stated with the estimate: 65%); the middle value lies on the limit itself.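

Carboxy in place of hydroxymethyl on this aromatic carbon gives an at least 11-fold higher number from compound 3 to compound 4 (1.06 log units; beyond the scatter) in this assay, so the loss now rests on a pair that differs in one place. Compound 4 reaches only a limit, > 60000 nM. The steps from compound 1 and from compound 2 to compound 4 cannot be read, with all three at one limit: the limit of > 60000 nM in this assay, at which 3 of the 4 values shown sit.

As far as these compounds go, how far the true value of compound 4 lies from that of compound 3 stays open. So does whether a methyl ester, a primary amide or an aminomethyl group at this position would keep the value of compound 3.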